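The source may report more compounds than this note shows. Statements on the series, on what has been measured and on what is new or still open speak of the compounds shown alone.

In a functional assay on HCT-116 cells (Homo sapiens) for antiproliferative activity, read by sulforhodamine B assay, with a stated time of 4 days (on this read-out higher numbers stand for weaker inhibition of growth and lower numbers for stronger inhibition of growth), compound 1 `CCNC(=O)CSc1nc(-c2cc(OCC)c(OC)cc2Cl)c2c(C#N)c[nH]c2n1` gives 40 nM, compound 2 `COc1cc(Cl)c(-c2nc(SCC(=O)NC(C)(C)C)nc3[nH]cc(C#N)c23)cc1O` gives 117 nM and compound 3 `COc1cc(Cl)c(-c2nc(SCC(=O)NC(C)(C)C)nc3[nH]cc(C#N)c23)cc1OC` gives 50 nM. Compound 3 thus lies within the scatter of compound 1, while compound 2 has a higher number beyond the scatter. Among the compounds with values here, the one measured step, a 2.3-fold lower number from compound 2 to compound 3 (0.37 log units; beyond the scatter), is a methyl in place of hydrogen on an oxygen on an aromatic ring. It concerns another part of the molecule, so it says little about compound 4 `COc1cc(Cl)c(-c2nc(SCC(=O)N3CCC3)nc3[nH]cc(C#N)c23)cc1OC`. This compound carries azetidin-1-yl in place of (tert-butyl)amino on a carbonyl carbon. Within the data shown here, no measured compound lacks the amide hydrogen, so the direction is uncertain. A modest rise is tentatively expected, a 2.4-fold higher number from compound 3 to compound 4 (0.38 log units; beyond the scatter). The estimate for compound 4 is 120 nM, within a range of 35 nM to 400 nM.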

Compound 4, concentration for 50% growth inhibition: 28 nM
The estimate for compound 4 lay 4.3-fold (0.63 log units) above the measured number; the measured number lies below the stated range.
By their numbers in this assay, from the lowest: compounds 4, 1 and 3 (each within the scatter of the next); then compound 2.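

Exchanging (tert-butyl)amino for azetidin-1-yl on the carbonyl carbon gives a 1.8-fold lower number from compound 3 to compound 4 (0.25 log units; within the scatter) in this assay, so the two compounds cannot be told apart in this assay. The amide hydrogen, present in compound 3 and absent from compound 4, is therefore not needed to keep this level of growth inhibition, at least in this pair, and a four-membered ring is accepted at this position. Nothing measured here explains why this is so.
From the compounds shown here alone, whether a larger ring such as piperidin-1-yl or morpholin-4-yl, or an open dimethylamino group, would fare alike stays open. So does whether azetidin-1-yl behaves the same way with other groups on the shared core.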